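Chloro Added to the Urea Aryl Ring of Compound 3

The source may report more compounds than this note shows. Statements on the series, on what has been measured and on what is new or still open speak of the compounds shown alone.

Compound 1, `COc1cc(-c2nn(-c3cccc(NC(=O)Nc4cc(C(F)(F)F)cc(C(F)(F)F)c4)c3)cc2-c2ccncc2)ccc1Cl`: 531 nM
Compound 2, `COc1cc(-c2nn(-c3cccc(NC(=O)c4cccc(C(F)(F)F)c4)c3)cc2-c2ccncc2)ccc1Cl`: 1660 nM
Compound 3, `COc1cc(-c2nn(-c3cccc(NC(=O)Nc4cccc(C(F)(F)F)c4)c3)cc2-c2ccncc2)ccc1Cl`: 573 nM

In a functional assay on KM12 cells (Homo sapiens) for inhibition, read by sulforhodamine B assay, with a stated time of 48 h (on this read-out higher numbers stand for weaker inhibition of growth and lower numbers for stronger inhibition of growth), compound 3 gives 573 nM, the second highest of the three numbers; its nearest neighbour is compound 1 and its furthest compound 2. The step of a 1.1-fold higher number from compound 1 to compound 3 (0.03 log units; within the scatter) lies within the scatter, so the two aryl ureas show no separation. Among the measured compounds shown here, the step of a 2.9-fold lower number from compound 2 to compound 3 (0.46 log units; beyond the scatter) is the only change beyond the scatter, and it concerns the urea link, not the aryl substituents.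

Compound 4, `COc1cc(-c2nn(-c3cccc(NC(=O)Nc4ccc(Cl)c(C(F)(F)F)c4)c3)cc2-c2ccncc2)ccc1Cl`, differs from compound 3 by chloro in place of hydrogen on an aromatic carbon, on an aromatic carbon of a six-membered aromatic ring of carbon only, ortho to a trifluoromethyl group and para to a large group. For the measured compounds named here, the one bearing step, a 1.1-fold higher number from compound 1 to compound 3 (0.03 log units; within the scatter), shows that adding or removing a substituent on this ring left the number within the scatter. Compound 4 is therefore expected to give about 500 nM, between 250 nM and 1100 nM, an estimated step of a 1.1-fold lower number from compound 3 to compound 4 (0.06 log units; within the scatter) and no change beyond the scatter.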

Compound 4, concentration for 50% growth inhibition: 1060 nM
The estimate for compound 4 lay 2.1-fold (0.33 log units) below the measured number, within the range that was stated.
By their numbers in this assay, from the lowest: compounds 1, 3, 4 and 2 (each within the scatter of the next, the first and the last beyond it).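

In this assay, among the compounds shown here, the step of a 1.8-fold higher number from compound 3 to compound 4 (0.27 log units; within the scatter) shows that chloro can enter the urea aryl ring at this carbon, ortho to a trifluoromethyl group and para to a large group, without a change beyond the scatter; the earlier compounds had tested no substituent at this place. The step of a 1.6-fold lower number from compound 2 to compound 4 (0.19 log units; within the scatter) adds a second point: the urea compound 3 stood apart from the amide compound 2 beyond the scatter, but the chloro-bearing urea compound 4 does not. Nothing available here bears on the reason for this result.

Going by these compounds, whether fluoro, methoxy or an amine at this same carbon would also stay within the scatter remains open. So does the outcome of chloro at this place on the amide compound 2.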